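Swapping Chloro for Methylamino on Compound 3

This account rests on a few compounds, and the source may have more. Where it says the series, first, only, none or still open, it means among the compounds named here.

Within the data shown here, in a functional assay on SW480 cells (Homo sapiens) for antiproliferative activity, read by MTT assay, with a stated time of 48 h (a higher number here means a weaker inhibitor, a lower number a stronger inhibitor), compound 3 (`CCCCCCCC(CCO)n1cnc2c(Cl)ncnc21`) gives 3630 nM, the only true number so far. Compound 1 (`CCC(CCO)n1cnc2c(Cl)ncnc21`) gives > 50000 nM, which is a limit and not a number. Compound 2 (`CCCCCCC(CCO)n1cnc2c(NC)ncnc21`) also carries methylamino and gives > 50000 nM, again a limit, which suggests a weaker result for compound 4. Overall, the data show (the limit of > 50000 nM in this assay, at which 2 of the 3 values shown sit).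

Compound 4 (`CCCCCCCC(CCO)n1cnc2c(NC)ncnc21`) keeps the chain of compound 3 but has methylamino in place of chloro on an aromatic carbon. Among the measured compounds shown here, the one measured step, an at least 13-fold lower number from compound 1 to compound 3 (1.13 log units; beyond the scatter), is large, but it changes the chain and leaves chloro in place. For the measured compounds named here, no measured step makes the chloro swap alone, so the evidence is indirect and the range must stay wide.

The expected change is a 4.1-fold higher number from compound 3 to compound 4 (0.62 log units; beyond the scatter), towards a weaker inhibitor and beyond the scatter. For compound 4 the estimated value is 15000 nM, with an expected range from 4000 nM to 50000 nM.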

Compound 4, half-maximal inhibitory concentration: 15300 nM
Estimate against measurement, compound 4: 1.0-fold (0.01 log units) below, within the range that was stated.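

In this assay, the swap of chloro for methylamino can now be read on its own with the chain held the same, and at this aromatic carbon, next to the ring nitrogen, it gives a 4.2-fold higher number from compound 3 to compound 4 (0.62 log units; beyond the scatter). With methylamino in place, the chain also counts: methyl in place of hydrogen on a saturated chain carbon, seven bonds along the chain from an aromatic nitrogen, gives an at least 3.2-fold lower number from compound 2 to compound 4 (0.51 log units; beyond the scatter). Compound 2 gives > 50000 nM, which is a limit and not a number, so the true size of this step stays unknown: the limit of > 50000 nM in this assay, at which 2 of the 4 values shown sit.

As far as these compounds go, it remains open whether a plain amine or a dimethylamino group at this carbon would give a number closer to that of compound 3 or of compound 4. A longer chain could also lower the number further, or it could not.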